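Chloro-substituted arylidene series: cytotoxic growth inhibition notes

The compounds below may be only part of what the source reports. "The series", "measured", "known", "first", "only" and "open" are said of these compounds alone.

Three measured compounds share one core. Compound 1 `O=C1NC(=S)/C(=C/c2cccc(Cl)c2)S1` gives 18.8% in a functional assay on HEp-2 cells (Homo sapiens) for cytotoxicity, read by MTT assay, with a stated time of 72 h, tested at 10 ug/mL; on this read-out higher numbers stand for more inhibition of growth at the one concentration tested and lower numbers for less inhibition of growth. Compound 2 `O=C1NC(=S)/C(=C/c2ccccc2Cl)S1` gives 21.2% in this assay; the two have the same atoms joined differently, and the difference between the two cores is not broken down here. Compound 3 `O=C1NC(=S)/C(=C/c2ccc(Cl)c(Cl)c2)S1` gives 16.4% in this assay. The change from compound 1 to compound 3 is chloro in place of hydrogen on an aromatic carbon, and it produced a number 2.4 percentage points lower from compound 1 to compound 3 (within the scatter).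

Compound 4 `O=C1NC(=S)/C(=C/c2ccc(Cl)cc2Cl)S1` is not yet measured. Its change from compound 2 is chloro in place of hydrogen on an aromatic carbon. This is the same kind of change as that from compound 1 to compound 3, but the entering chloro sits meta to a chloro group rather than ortho to a chloro group. Resting on the value of compound 2 in this assay, 21.2%, and on the step of a number 2.4 percentage points lower from compound 1 to compound 3 (within the scatter), the expected step is a number 2.2 percentage points lower from compound 2 to compound 4 (within the scatter). Compound 4 is accordingly estimated at 19%, with a likely range from 8% to 30%.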

Compound 4, percent growth inhibition at one concentration: 24.8%
Beside the measured number, compound 4's estimate is 5.8 percentage points below it; the measured number falls inside the stated range.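

In this assay, chloro in place of hydrogen on an aromatic carbon, meta to a chloro group, gives a number 3.6 percentage points higher from compound 2 to compound 4 (within the scatter) on the core of compound 2. These two pairs do not show that the change has an effect of either sign on growth inhibition, nor how it would behave on further cores. As far as they go, the change carries between the two cores with no difference that can be told apart: the same change on two cores in this assay, a number 2.4 percentage points lower (within the scatter) from compound 1 to compound 3 and a number 3.6 percentage points higher (within the scatter) from compound 2 to compound 4, 6 percentage points apart, within the scatter of two such steps

Still open, from the compounds shown here alone, is whether a different group on the aromatic ring, such as an amine, a carboxylic acid or a methoxy group, would move growth inhibition beyond the usual scatter. Going by these compounds, a longer chain in place of a chloro group remains equally open.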